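A Carboxyphenyl in Place of an Isoquinolinyl Side Group

The source may hold more compounds than are shown below. What is called first, only, known or untested is meant among the compounds shown, and "the series" means these compounds.

Compound 1, `CC1(C)CCC[C@]2(C)[C@@H](CC[C@@](C)(O)/C=C/c3cccc([N+](=O)[O-])c3)[C@](C)(O)CC[C@@H]12`: 3380 nM
Compound 2, `CC1(C)CCC[C@]2(C)[C@@H](CC[C@@](C)(O)/C=C/c3cncc4ccccc34)[C@](C)(O)CC[C@@H]12`: 46000 nM

Among the compounds with values here, in a functional assay on HeLa cells (Homo sapiens) for cytotoxicity, read by MTT assay, with a stated time of 48 h (on this read-out lower numbers stand for stronger inhibition and higher numbers for weaker inhibition), compound 2 stands highest of the two numbers measured so far, with compound 1 as its only neighbour a long way below. Within the data shown here, the single measured step, a 14-fold higher number from compound 1 to compound 2 (1.13 log units; beyond the scatter), came with isoquinolin-4-yl in place of 3-nitrophenyl on a double-bonded chain carbon bound to a double-bonded chain carbon, and it was large.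

Compound 3, `CC1(C)CCC[C@]2(C)[C@@H](CC[C@@](C)(O)/C=C/c3ccc(C(=O)O)cc3)[C@](C)(O)CC[C@@H]12`, has not yet been measured in this assay. It differs from compound 2 by 4-carboxyphenyl in place of isoquinolin-4-yl on a double-bonded chain carbon bound to a double-bonded chain carbon. Among the measured compounds shown here, the one measured step bears on this change only loosely: it shows that removing a substituted phenyl for isoquinolin-4-yl raised the number sharply, so the reverse direction, a substituted phenyl returning, is expected to lower it, though the carboxy group and its position are both new and unsupported by any measured pair. A moderate downward step, a 3.8-fold lower number from compound 2 to compound 3 (0.58 log units; beyond the scatter), is therefore expected, with wide uncertainty. For compound 3 the estimate in this assay is 12000 nM, ranging from 3000 nM to 45000 nM.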

Compound 3, half-maximal inhibitory concentration: 45400 nM
Estimate against measurement, compound 3: 3.8-fold (0.58 log units) below, outside the stated range (above it).
By their numbers in this assay, from the lowest: compound 1; then compounds 3 and 2 (each within the scatter of the next).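

In this assay the change gave a 1.0-fold lower number from compound 2 to compound 3 (0.01 log units; within the scatter), so 4-carboxyphenyl and isoquinolin-4-yl cannot be told apart on a double-bonded chain carbon bound to a double-bonded chain carbon. A phenyl ring at this place does not by itself bring back the number of compound 1: the swap of 3-nitrophenyl for 4-carboxyphenyl gave a 13-fold higher number from compound 1 to compound 3 (1.13 log units; beyond the scatter), a step of the same size as the one that came with isoquinolin-4-yl. Among these three groups only 3-nitrophenyl stands apart, and nothing available here accounts for the difference.

Going by these compounds, it remains open how a plain phenyl would stand at this place, and so whether the nitro group or the carboxylic acid is what sets the numbers. A methyl ester of the carboxylic acid could stay with compound 3 or move toward compound 1.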